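A few compounds are considered here, and "the series" means these few. Any claim that something is new, unique, unknown or untested is made for them only; others in the source may bear on it.

Going by the values given here, in a functional assay on A-375 cells (Homo sapiens) for antiproliferative activity, read by trypan blue exclusion and crystal violet staining, with a stated time of 72 h (on this read-out higher numbers stand for weaker inhibition and lower numbers for stronger inhibition), only two compounds have numbers so far. Compound 1 (`CCCCOc1ccnc2c(O)c(CNC(=O)C3CCCCC3)ccc12`) gives 540 nM, and compound 2 (`CCCC(=O)NC(c1ccc(C)cc1)c1cc(Cl)c2cccnc2c1O`) gives 120 nM. Compound 2 therefore holds the lower of the two numbers, and its gap to compound 1 lies beyond the usual scatter of repeated measurements. Compound 3 (`CCCC(=O)NC(c1ccccc1)c1cc(Cl)c2cccnc2c1O`) is still unmeasured. It departs from compound 2 in one place: hydrogen in place of methyl on an aromatic carbon, so that 4-methylphenyl becomes phenyl. Among the compounds with values here, no measured pair shows this change, so the expectation starts from compound 2 at 120 nM. No step beyond the scatter is expected in this assay, though the number may come out slightly higher. The estimated step is a 1.2-fold higher number from compound 2 to compound 3 (0.07 log units; within the scatter). For compound 3 the expected value is 140 nM, with an estimated range from 50 nM to 400 nM.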

Compound 3, half-maximal inhibitory concentration: 130 nM
Beside the measured number, compound 3's estimate is 1.1-fold (0.03 log units) above it; low and high end bracket the measured number.
By their numbers in this assay, from the lowest: compounds 2 and 3 (each within the scatter of the next); then compound 1.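

With compound 3, this assay gains its first pair of compounds that differ in one place: hydrogen in place of methyl on an aromatic carbon, para to a large group, gives a 1.1-fold higher number from compound 2 to compound 3 (0.03 log units; within the scatter). On this read-out, the 4-methylphenyl of compound 2 and the phenyl of compound 3 cannot be told apart, so in this pair the methyl is not needed to keep the number at this level. No measurement at hand speaks to why the two numbers lie so close.

What the compounds shown leave open is whether a methoxy group, a chlorine or a carboxylic acid on that same carbon would also stay within the scatter of compound 3. They also leave open how a longer chain or an amine in place of the amide chain would read.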